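Turning One Ring Stereocentre in Compound 3

The compounds below may be only part of what the source reports. "The series", "measured", "known", "first", "only" and "open" are said of these compounds alone.

Compound 3 `O=C(O)[C@H]1NC[C@H](O)[C@@H](O)[C@@H]1O` has the lowest of three closely spaced numbers. In an assay for inhibition of alpha-N-acetylgalactosaminidase (Gallus gallus), tested at 1000 uM (on this read-out higher numbers stand for more inhibition at the one concentration tested (going by the name of the read-out) and lower numbers for less inhibition), compound 3 gives 0.2%. Compound 2 `O=C(O)[C@@H]1NC[C@@H](O)[C@@H](O)[C@@H]1O` gives 7.2% in this assay, and compound 1 `O=C(O)[C@@H]1NC[C@@H](O)[C@H](O)[C@@H]1O` gives 10%. The gaps are small: a number 9.8 percentage points lower from compound 1 to compound 3 (within the scatter) and a number 7 percentage points lower from compound 2 to compound 3 (within the scatter), so none of the three can be called weaker or stronger than another.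

Compound 4 `O=C(O)[C@H]1NC[C@H](O)[C@H](O)[C@@H]1O` has not yet been measured. the two compounds have the same atoms and bonds and differ only in configuration as drawn: 1 of 4 stereo elements differ; a stereocentre at a saturated ring carbon is drawn R in compound 3 and S in compound 4

All three measured pairs also differ only in configuration as drawn the fact that compounds 1 and 2 differ only in the configuration as drawn the fact that compounds 1 and 3 differ only in the configuration as drawn (the fact that compounds 2 and 3 differ only in the configuration as drawn), so each of them bears on this change. The step closest in kind, a single stereocentre, is a number 2.8 percentage points lower from compound 1 to compound 2 (within the scatter). The larger configurational changes, a number 7 percentage points lower from compound 2 to compound 3 (within the scatter) and a number 9.8 percentage points lower from compound 1 to compound 3 (within the scatter), also stayed within the scatter. On this basis the change from compound 3 to compound 4 is expected to be small, and a number 4.8 percentage points higher from compound 3 to compound 4 (within the scatter) is the step the estimate implies. Compound 4 is therefore expected to give 5% in this assay, with a range from 0% to 18%.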

Compound 4, a percentage reported as inhibition, at one concentration (the size of the read-out at that concentration, not a potency): 4.5%
Beside the measured number, compound 4's estimate is 0.5 percentage points above it; the measured number falls inside the stated range.
By their numbers in this assay, from the lowest: compounds 3, 4, 2 and 1 (each within the scatter of the next).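

Drawing this one ring stereocentre as S in compound 4 rather than R in compound 3 gives a number 4.3 percentage points higher from compound 3 to compound 4 (within the scatter) in this assay, so this single turn has no readable effect on the read-out at the one concentration tested. The wider configurational comparisons that compound 4 adds agree, with a number 2.7 percentage points lower from compound 2 to compound 4 (within the scatter) where three stereo elements differ and a number 5.5 percentage points lower from compound 1 to compound 4 (within the scatter) where two differ, so the four compounds cannot be told apart in this assay. The step from compound 3 to compound 4 is a clean test of configuration, since nothing else separates the pair: the fact that compounds 3 and 4 differ only in the configuration as drawn

All four compounds carry the same carboxylic acid, so they leave open whether configuration would matter with a hydroxymethyl group in its place. They also leave open what a longer alkyl chain on the amine nitrogen of the shared core would do.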